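A few compounds are considered here, and "the series" means these few. Any claim that something is new, unique, unknown or untested is made for them only; others in the source may bear on it.

Measured so far:
compound 1 `CC1=C(C(=O)OCC(C)C)C(c2ccoc2)NC(=O)N1` gives 326 nM
compound 2 `CC1=C(C(=O)OCC(C)C)C(c2cccs2)NC(=O)N1` gives 2130 nM
compound 3 `CC1=C(C(=O)OCC2CCC2)C(c2ccco2)NC(=O)N1` gives 561 nM

In an assay on membranes from HEK293 cells for displacement of a labelled ligand from adenosine receptor A2b (Homo sapiens), read by scintillation counting, with a stated time of 30 min (a higher number here means a weaker inhibitor, a lower number a stronger inhibitor), compound 1 stands at the lowest of the three numbers with 326 nM. Compound 3, at 561 nM, sits within the scatter of compound 1, so no order between the two can be drawn. For the measured compounds named here, compound 2 gives 2130 nM, and the step of a 6.5-fold higher number from compound 1 to compound 2 (0.82 log units; beyond the scatter) is the only single-point change among the measured compounds.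

Compound 4 `CC1=C(C(=O)OC2CCC2)C(c2ccoc2)NC(=O)N1` differs from compound 1 by cyclobutyl in place of isobutyl on an oxygen next to a carbonyl group. The measured step from compound 1 to compound 2 concerns the ring on the saturated ring carbon, not the group on the oxygen next to a carbonyl group, and so does not bear on this change. Going by the values given here, compound 3 differs from compound 1 in two places at once, and its two values show only that a compound carrying a four-membered ring on that oxygen sits within the scatter of compound 1. With nothing measured on this change alone, the step from compound 1 to compound 4 is expected to be a 1.2-fold higher number from compound 1 to compound 4 (0.09 log units; within the scatter), not beyond the scatter. Compound 4 is therefore estimated at 400 nM, with a range from 150 nM to 1100 nM.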

Compound 4, inhibition constant: 307 nM
Compound 4: middle estimate off by 1.3-fold (0.11 log units), on the high side, and the stated range covers the measured number.
By their numbers in this assay, from the lowest: compounds 4, 1 and 3 (each within the scatter of the next); then compound 2.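

In this assay, cyclobutyl in place of isobutyl on an oxygen next to a carbonyl group gives a 1.1-fold lower number from compound 1 to compound 4 (0.03 log units; within the scatter) and so leaves the two compounds indistinguishable. With furan-3-yl held fixed, this position therefore accepts a closed four-membered ring of carbon in place of an open chain with the same count of heavy atoms, a reading that compound 3, which differs from compound 1 in two places at once, could not give. Nothing available explains why the two groups match in this assay.

Still open, from the compounds shown here alone, is whether cyclobutyl and isobutyl also match when thiophen-2-yl takes the place of furan-3-yl. The compounds shown also leave open what a longer chain, a cyclohexyl group or a benzyl group on that oxygen would give.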